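A few compounds are considered here, and "the series" means these few. Any claim that something is new, unique, unknown or untested is made for them only; others in the source may bear on it.

Working notes on the series. Within the data shown here, compound 3 `CCCC1C(C(=O)OCc2ccccn2)=C(C)NC2=C1C(=O)CCC2` gives 2.6 in a physicochemical assay for lipophilicity, measured as octanol-water partition (a higher number here means a more lipophilic compound, a lower number a more polar compound), the highest of the three numbers so far; compound 1 `CC1=C(C(=O)OCc2ccccn2)C(c2ccc(Cl)cc2)C2=C(CCCC2=O)N1` gives 2.24 and compound 2 `CC1=C(C(=O)OCc2ccccn2)C(c2ccccc2[N+](=O)[O-])C2=C(CCCC2=O)N1` gives 1.88. Both aryl-bearing compounds sit lower than compound 3, by a number 0.36 log units higher from compound 1 to compound 3 (beyond the scatter) and a number 0.72 log units higher from compound 2 to compound 3 (beyond the scatter) when read toward compound 3. Compound 4 `CC1=C(C(=O)OCc2ccccn2)C(c2ccccc2)C2=C(CCCC2=O)N1` reverses that kind of move: phenyl in place of propyl on a saturated ring carbon. Those two steps are the ones that bear on it; each was modest and beyond the scatter, and both carried a substituted phenyl, whereas phenyl itself has not been measured in this series. A downward step is therefore expected for compound 4, estimated as a number 0.75 log units lower from compound 3 to compound 4 (beyond the scatter), landing near the two aryl compounds. Compound 4 is estimated at 1.85, with a range from 1.4 to 2.3.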

Compound 4, partition coefficient: 2.72
Beside the measured number, compound 4's estimate is 0.87 log units below it, outside the stated range (above it).
By their numbers in this assay, from the lowest: compound 2; then compound 1; then compounds 3 and 4 (each within the scatter of the next).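

In this assay, phenyl in place of propyl on the saturated ring carbon gives a number 0.12 log units higher from compound 3 to compound 4 (within the scatter), so the larger ring and the chain read alike at this position. The gaps seen earlier belong to the substituted phenyls, not to phenyl itself: hydrogen in place of chloro gives a number 0.48 log units higher from compound 1 to compound 4 (beyond the scatter), and hydrogen in place of nitro gives a number 0.84 log units higher from compound 2 to compound 4 (beyond the scatter). Nothing available explains these steps.

Still open, on these data alone, is how a longer chain or an amine would read on this saturated ring carbon. A carboxylic acid on the phenyl also remains an open case.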